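This account rests on a few compounds, and the source may have more. Where it says the series, first, only, none or still open, it means among the compounds named here.

Measured compounds:
- compound 1 `O=C1O/C(=C\Cn2cnc3c(Cl)c(F)nc(F)c32)C(OCc2ccccc2)=C1OCc1ccccc1`: "not determined" (no result reported) in a functional assay on CCRF-CEM cells (Homo sapiens) for antiproliferative activity, read by MTT assay, with a stated time of 72 h; on this read-out higher numbers stand for weaker inhibition and lower numbers for stronger inhibition
- compound 2 `O=C1O/C(=C\Cn2cnc3cc[nH]c3c2=O)C(OCc2ccccc2)=C1OCc1ccccc1`: 16000 nM

For the measured compounds named here, compound 2 is the only compound with a number in this assay, so it stands alone there, and compound 1 adds nothing to compare against. Compound 3 `O=C1O/C(=C\Cn2cnc3cncc(Br)c32)C(OCc2ccccc2)=C1OCc1ccccc1` differs from compound 2 in one place: a group of 10 heavy atoms (6 carbon, 3 nitrogen, 1 bromine; one five-membered aromatic ring with 2 hetero atoms, one six-membered aromatic ring with 1 hetero atom) in place of a group of 10 heavy atoms (6 carbon, 3 nitrogen, 1 oxygen; one five-membered aromatic ring with 1 hetero atom, one six-membered aromatic ring with 2 hetero atoms), on a saturated chain carbon bound to a double-bonded chain carbon. Going by the values given here, because compound 2 gives only 16000 nM in this assay and no comparable step is known, the direction of change is uncertain. The step from compound 2 to compound 3 is expected to be small, with the estimate a 1.6-fold lower number from compound 2 to compound 3 (0.20 log units; within the scatter). Compound 3 is therefore expected near 10000 nM, within 2000 nM to 50000 nM.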

Compound 3, half-maximal inhibitory concentration: 5700 nM
The estimate for compound 3 lay 1.8-fold (0.24 log units) above the measured number, and the stated range covers the measured number.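

In this assay, for the compounds shown here, the first step that can be read at this place, on a saturated chain carbon bound to a double-bonded chain carbon, shows that exchanging the group there can change the result beyond the scatter: a 2.8-fold lower number from compound 2 to compound 3 (0.45 log units; beyond the scatter), toward stronger inhibition. The exchange swaps an oxygen-bearing group with a hydrogen-bond donor for a bromine-bearing group without one, and it also alters both rings, so no single feature can be credited. No measurement shown explains the difference. It remains open whether the bromine itself matters, since no compound shown carries a chlorine, an amine or plain hydrogen in its place.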